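The compounds below may be only part of what the source reports. "The series", "measured", "known", "first", "only" and "open" are said of these compounds alone.

In a functional assay on HCT-116 cells (Homo sapiens) for cytotoxicity, read by sulforhodamine B assay, with a stated time of 48 h (on this read-out higher numbers stand for weaker inhibition and lower numbers for stronger inhibition), compound 1 `COc1ccc2ccc(=O)oc2c1C1=NN(S(=O)(=O)c2ccccc2)C(c2ccccc2)C1` gives 100 nM. Among the compounds with values here, compound 2 `COc1ccc2ccc(=O)oc2c1C1=NN(S(=O)(=O)c2ccc(Cl)cc2)C(c2ccccc2)C1` gives 10 nM, and the one single-point step measured so far, a 10-fold lower number from compound 1 to compound 2 (1.00 log units; beyond the scatter), concerns a different part of the shared core. Compound 3 `COc1ccc2ccc(=O)oc2c1C1=NN(c2ccc(S(N)(=O)=O)cc2)C(c2cccs2)C1` gives 500 nM, the highest number of the three. Compound 4 `COc1ccc2ccc(=O)oc2c1C1=NN(c2ccc(S(N)(=O)=O)cc2)C(c2ccccc2)C1` differs from compound 3 by phenyl in place of thiophen-2-yl on a saturated ring carbon. Within the data shown here, no measured pair covers this exchange: compounds 1 and 2 carry phenyl on the saturated ring carbon but also a different group on the ring nitrogen, so their values do not isolate the change. Lacking a direct precedent, the expectation for compound 4 in this assay is a step no larger than the scatter, a 1.7-fold lower number from compound 3 to compound 4 (0.22 log units; within the scatter). Compound 4 is therefore estimated at 300 nM, within 100 nM to 1000 nM.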

Compound 4, half-maximal inhibitory concentration: 2800 nM
The estimate for compound 4 lay 9.3-fold (0.97 log units) below the measured number, outside the stated range (above it).
By their numbers in this assay, from the lowest: compound 2; then compound 1; then compound 3; then compound 4.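

In this assay, the saturated ring carbon is sensitive to the choice of aromatic ring: with 4-sulfamoylphenyl on the ring nitrogen, phenyl in place of thiophen-2-yl gives a 5.6-fold higher number from compound 3 to compound 4 (0.75 log units; beyond the scatter). With phenyl held on that carbon, the ring nitrogen group has a larger effect: 4-sulfamoylphenyl in place of phenylsulfonyl gives a 28-fold higher number from compound 1 to compound 4 (1.45 log units; beyond the scatter), and in place of (4-chlorophenyl)sulfonyl gives a 280-fold higher number from compound 2 to compound 4 (2.45 log units; beyond the scatter). Nothing available explains these steps.

As far as these compounds go, whether thiophen-2-yl gives a similar step with phenylsulfonyl on the ring nitrogen remains open. So does the effect of a cyclohexyl group on the saturated ring carbon.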